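This account rests on a few compounds, and the source may have more. Where it says the series, first, only, none or still open, it means among the compounds named here.

Compound 1 `O=C(OC1CCC(CN2CCN(c3cc(=O)c4cc(C(F)(F)F)cc([N+](=O)[O-])c4s3)CC2)CC1)C1CCCCC1` and compound 2 `O=C(OC1CCC(CN2CCN(c3cc(=O)c4cc(C(F)(F)F)cc([N+](=O)[O-])c4s3)CC2)CC1)c1ccco1` share one core and differ only at the carbonyl carbon. In an ADME assay on cells (Hepatocyte, Mus musculus) for metabolic stability (a lower number here means that the compound disappears faster, a higher number that the compound lasts longer), compound 1 gives 0.0783 h. Compound 2 reaches only a limit of this assay, < 0.075 h, so its standing is a bound rather than a number (the limit of < 0.075 h in this assay, at which 1 of the 2 values shown sits). Among the measured compounds shown here, the single measured step, an at least 1.0-fold lower number from compound 1 to compound 2 (0.01 log units; that floor lies within the scatter), lies within the scatter. Compound 3 `CS(=O)(=O)NC1CCC(CN2CCN(c3cc(=O)c4cc(C(F)(F)F)cc([N+](=O)[O-])c4s3)CC2)CC1` differs from compound 2 by methanesulfonamido in place of ((furan-2-yl)carbonyl)oxy on a saturated ring carbon. For the measured compounds named here, no measured step involves a methanesulfonamido group, so no step beyond the scatter is expected. Compound 3 is therefore estimated at 0.09 h, between 0.04 h and 0.3 h. That estimate means a step of an at least 1.2-fold higher number from compound 2 to compound 3 (0.07 log units; that floor lies within the scatter).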

Compound 3, half-life: > 1.55 h
Compound 3: only a limit was reported; the forecaster's own chance of this, stated with the estimate: 45%; at least 17-fold (1.23 log units) between middle value and limit.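

At this saturated ring carbon, methanesulfonamido in place of ((furan-2-yl)carbonyl)oxy gives an at least 20-fold higher number from compound 2 to compound 3 (1.31 log units; beyond the scatter), and in place of (cyclohexylcarbonyl)oxy it gives an at least 19-fold higher number from compound 1 to compound 3 (1.29 log units; beyond the scatter). Among these compounds, the change on the saturated ring carbon therefore produces steps beyond the scatter, whereas the printed floor of the step on the carbonyl carbon lies within it. In this assay compound 3 gives > 1.55 h, a limit and not a number: the limit of > 1.55 h in this assay, at which 1 of the 3 values shown sits.

The compounds shown leave open whether the large step depends on methanesulfonamido itself or follows from losing either carbonyloxy group. A primary amine or an acetamide on this ring carbon would help separate those two readings.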